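Notes on a Chloro-to-Trifluoromethyl Swap in the Series

The source may hold more compounds than are shown below. What is called first, only, known or untested is meant among the compounds shown, and "the series" means these compounds.

Measured so far:
compound 1 `O=C(Nc1cccc(-n2cc(-c3ccncc3)c(-c3ccc(Cl)c(O)c3)n2)c1)Nc1ccc(Cl)c(Cl)c1`: 1550 nM
compound 2 `O=C(Nc1cccc(-n2cc(-c3ccncc3)c(-c3ccc(Cl)c(O)c3)n2)c1)Nc1cc(C(F)(F)F)cc(C(F)(F)F)c1`: 1820 nM

In a functional assay on T47D cells (Homo sapiens) for inhibition, read by sulforhodamine B assay, with a stated time of 48 h (a lower number here means a stronger inhibitor of growth, a higher number a weaker inhibitor of growth), compound 1 gives 1550 nM, the lowest of the two numbers shown. Compound 2 gives 1820 nM in this assay; the gap to compound 1 lies within the scatter, so no order between the two is claimed.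

Compound 3 `O=C(Nc1cccc(-n2cc(-c3ccncc3)c(-c3ccc(Cl)c(O)c3)n2)c1)Nc1ccc(Cl)c(C(F)(F)F)c1` has not yet been measured in this assay. It differs from compound 1 in one place: trifluoromethyl in place of chloro on an aromatic carbon. Going by the values given here, no measured pair shows this exact change, so its size is not known from the data. What is known is that compound 2, which also carries trifluoromethyl in the same part of the molecule, gives 1820 nM, within the scatter of compound 1. On that basis a step in this assay of no more than the scatter is expected, in either direction.

For compound 3 the value in this assay is expected near 1650 nM, with a range from 700 nM to 3800 nM. This estimate means a step of a 1.1-fold higher number from compound 1 to compound 3 (0.03 log units; within the scatter), expected to stay within the scatter.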

Compound 3, concentration for 50% growth inhibition: 1120 nM
Compound 3: middle estimate off by 1.5-fold (0.17 log units), on the high side; the range from low to high includes it.
By their numbers in this assay, from the lowest: compounds 3, 1 and 2 (each within the scatter of the next).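

The swap of trifluoromethyl in place of chloro on an aromatic carbon, ortho to a chloro group, can now be read directly: in this assay it gives a 1.4-fold lower number from compound 1 to compound 3 (0.14 log units; within the scatter) and so sets no order between the two compounds. At this position, a group of 4 heavy atoms stands where a group of 1 heavy atom stood, and the growth-inhibition read-out does not separate the pair. The data shown hold nothing that could account for this reading.

Open is how an amine, a carboxylic acid or a longer chain on this same aromatic carbon would read in this assay, since the substituents shown at this place are limited to chloro and trifluoromethyl, and these two give a single pair with one difference. Also open, on these data alone, is whether trifluoromethyl in place of the remaining chloro group of compound 3 would stay within the scatter, or whether a step beyond it would appear there.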